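The source may report more compounds than this note shows. Statements on the series, on what has been measured and on what is new or still open speak of the compounds shown alone.

Three compounds share one core, an amide with a free amine on the neighbouring aromatic ring, joined through a double bond to a benzyl sulfide whose aryl group varies. Compound 1 `COc1ccc(SCc2ccc(/C=C/C(=O)Nc3ccccc3N)cc2)cc1OC` gives 46% in a functional assay on A-375 cells (Homo sapiens) for inhibition, read by CCK-8 assay, with a stated time of 72 h, tested at 2 uM; on this read-out lower numbers stand for less inhibition of growth and higher numbers for more inhibition of growth at the one concentration tested. Compound 2 `Nc1ccccc1NC(=O)/C=C/c1ccc(CSc2ccc(Cl)cc2)cc1` gives 13.4% in this assay, and compound 3 `Nc1ccccc1NC(=O)/C=C/c1ccc(CSc2cccc(F)c2)cc1` gives 6.75%. On these numbers compound 3 holds the smallest value of the three: the larger gap is a number 39.3 percentage points lower from compound 1 to compound 3 (beyond the scatter), while the smaller gap, a number 6.7 percentage points lower from compound 2 to compound 3 (within the scatter), is within the scatter, so compound 2 and compound 3 cannot be told apart.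

Compound 4 `Nc1ccccc1NC(=O)/C=C/c1ccc(CSc2cccc3ccccc23)cc1` differs from compound 3 in one place: naphthalen-1-yl in place of 3-fluorophenyl on a sulfur. Going by the values given here, the steps that bear on this position are a number 32.6 percentage points lower from compound 1 to compound 2 (beyond the scatter) and a number 39.3 percentage points lower from compound 1 to compound 3 (beyond the scatter), both large, and a number 6.7 percentage points lower from compound 2 to compound 3 (within the scatter), which is within the scatter. Among the compounds with values here, no measured step involves a two-ring aryl group, so the direction is uncertain. The expected step is a number 8.3 percentage points higher from compound 3 to compound 4 (within the scatter), a small change. Compound 4 is therefore estimated at 15%, with a range from 2% to 40%.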

Compound 4, percent growth inhibition at one concentration: 1.55%
Estimate against measurement, compound 4: 13.5 percentage points above; the whole stated range lies above it.
By their numbers in this assay, from the lowest: compounds 4, 3 and 2 (each within the scatter of the next, the first and the last beyond it); then compound 1.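

Moving from a one-ring to a two-ring aryl group on the sulfur gives no clear change in this assay: the result is a number 5.2 percentage points lower from compound 3 to compound 4 (within the scatter), so adding a second aromatic ring does not bring back the growth inhibition seen with compound 1. The other comparisons are a number 11.9 percentage points lower from compound 2 to compound 4 (beyond the scatter) and a number 44.5 percentage points lower from compound 1 to compound 4 (beyond the scatter), which leave the 3,4-dimethoxyphenyl group of compound 1 well above naphthalen-1-yl and show that 4-chlorophenyl and naphthalen-1-yl can be told apart. No measurement here explains these differences.

On these data alone, it remains open whether a phenyl ring with one methoxy group would keep the number of compound 1 or whether both methoxy groups are needed. As far as these compounds go, how an amine or a carboxylic acid on the aryl group would read in this assay is also open.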